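The source may report more compounds than this note shows. Statements on the series, on what has been measured and on what is new or still open speak of the compounds shown alone.

Measured in an ADME assay on HepG2 cells (Homo sapiens) for cytotoxicity, read by CellTiter-Glo and ATP content, with a stated time of 72 h; a higher number here means that more compound is needed for the effect, a lower number that less compound is needed:

- compound 2 `CS(=O)(=O)c1ccc(C(=O)NCC(=O)N2CCCCC2)cc1[N+](=O)[O-]`: 14000 nM
- compound 1 `CN(Cc1ccccc1F)C(=O)CNC(=O)c1ccc(S(C)(=O)=O)c([N+](=O)[O-])c1`: 11400 nM
- compound 3 `Cc1ccc(N2CCN(C(=O)CCCNC(=O)c3ccc(S(C)(=O)=O)c([N+](=O)[O-])c3)CC2)cc1`: > 27000 nM, a limit of the assay, not a number

Compound 2 gives the highest of the two numbers in this assay, but its nearest neighbour, compound 1 at 11400 nM, sits within the scatter of it, so the two are not separable. For compound 3 only a limit is reported (the limit of > 27000 nM in this assay, at which 1 of the 3 values shown sits).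

The next compound, compound 4 `CN(Cc1ccccc1)C(=O)CNC(=O)c1ccc(S(C)(=O)=O)c([N+](=O)[O-])c1`, is drawn from compound 2 by one change: benzyl(methyl)amino in place of piperidin-1-yl on a carbonyl carbon. Within the data shown here, no measured step of this kind stands in the set, so the expectation rests on the spread of the numbers themselves. Since compound 1, which carries a related amide substituent, gives 11400 nM and sits within the scatter of compound 2, the expected step of a 1.2-fold lower number from compound 2 to compound 4 (0.07 log units; within the scatter) is none beyond the scatter. Compound 4 is estimated at 12000 nM, with a range from 6000 nM to 25000 nM.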

Compound 4, half-maximal effective concentration: > 27000 nM
Compound 4: a limit, no number (the forecaster's own chance of this, stated with the estimate: 20%); middle value at least 2.2-fold (0.35 log units) from the limit.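

In this assay compound 4 returns a limit, not a number, the same limit as compound 3: the limit of > 27000 nM in this assay, at which 2 of the 4 values shown sit.

With benzyl(methyl)amino in place of piperidin-1-yl on a carbonyl carbon, the series shows an at least 1.9-fold higher number from compound 2 to compound 4 (0.28 log units; that floor lies within the scatter), so this change alone is not shown to move the number. Hydrogen in place of fluoro on an aromatic carbon gives an at least 2.3-fold higher number from compound 1 to compound 4 (0.37 log units; beyond the scatter), the first step in the set beyond the scatter, which shows that this single atom separates two otherwise matching compounds in this assay.

Going by these compounds, compound 4 carries only a limit, so the true size of both steps stays open. Also open, on these data alone, is whether chloro or methoxy on that aromatic carbon, or morpholin-4-yl on the carbonyl carbon, would give a number or another limit.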